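Benzamide in place of the pyridin-3-yl carboxamide

A few compounds are considered here, and "the series" means these few. Any claim that something is new, unique, unknown or untested is made for them only; others in the source may bear on it.

Of the compounds shown here, three have been measured in a functional assay on NALM-6 cells (Homo sapiens) for cytotoxicity, read by MTT assay, with a stated time of 48 h; a higher number here means a weaker inhibitor, a lower number a stronger inhibitor. Compound 1 `CCN(CC)c1ccc(C(F)(F)F)cc1NC(=O)c1cccnc1` gives 63200 nM. Compound 2 `O=C(Nc1cc(C(F)(F)F)ccc1NC1CCCCC1)c1ccncc1` gives 59000 nM. Compound 3 `O=C(Nc1cc(C(F)(F)F)ccc1NC1CCCCC1)c1cccnc1` gives 52300 nM. All three numbers sit within the scatter of one another, so compound 1 cannot be set apart from the other two on these data.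

Compound 4 `CCN(CC)c1ccc(C(F)(F)F)cc1NC(=O)c1ccccc1` differs from compound 1 by phenyl in place of pyridin-3-yl on a carbonyl carbon. For the measured compounds named here, no measured step swaps pyridin-3-yl for phenyl, so the comparison is indirect. Going by the values given here, the only step touching the group on the carbonyl carbon is a 1.1-fold lower number from compound 2 to compound 3 (0.05 log units; within the scatter), which stayed within the scatter. The step on the amine, a 1.2-fold lower number from compound 1 to compound 3 (0.08 log units; within the scatter), was equally flat. Among the compounds with values here, nothing in this assay so far has moved a number beyond the scatter, and the expected step of a 1.1-fold lower number from compound 1 to compound 4 (0.02 log units; within the scatter) is therefore also within the scatter, with no direction favoured. Compound 4 is estimated at 60000 nM, with a range from 25000 nM to 150000 nM.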

Compound 4, half-maximal inhibitory concentration: "not active" (no number reported)
The entry for compound 4 holds no number; the estimate stays without a comparison.
By their numbers in this assay, from the lowest: compounds 3, 2 and 1 (each within the scatter of the next).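

For the compounds shown here, compound 4 stands in this assay as "not active" with no number, so no step from compound 1 can be read. The compounds shown leave open whether phenyl in place of pyridin-3-yl on a carbonyl carbon changes the number at all. No evidence on this result is available.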